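Working notes: chloro in place of acetyl on the phenyl ring

The source may report more compounds than this note shows. Statements on the series, on what has been measured and on what is new or still open speak of the compounds shown alone.

Of the compounds shown here, two of this set have been measured in a functional assay on NCI-H23 cells (Homo sapiens) for inhibition, read by sulforhodamine B assay, with a stated time of 48 h, tested at 10 uM; a higher number here means more inhibition at the concentration tested (going by the name of the read-out), a lower number less inhibition. Compound 1, `c1ccc(-c2cn3ccnc3c(-c3ccc4ncn(C5CCCCC5)c4c3)n2)cc1`, gives 45.3%. Compound 2, `CC(=O)c1ccc(-c2cn3ccnc3c(-c3ccc4ncn(C5CCCCC5)c4c3)n2)cc1`, gives 8.6%. Going by the values given here, the single step measured so far, a number 36.7 percentage points lower from compound 1 to compound 2 (beyond the scatter), is large and beyond the scatter, so compound 2 stands as the lowest of the two numbers, with compound 1 the nearest and clearly higher.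

Compound 3, `Clc1ccc(-c2cn3ccnc3c(-c3ccc4ncn(C5CCCCC5)c4c3)n2)cc1`, is not yet measured. Its difference from compound 2 is chloro in place of acetyl on an aromatic carbon. Cut one bond further out, the change reads 4-acetylphenyl to 4-chlorophenyl.

Among the compounds with values here, the only measured step that bears on this is the one from compound 1 to compound 2, where an acetyl entering on that aromatic carbon lowered inhibition well beyond the scatter. Within the data shown here, compound 3 removes that acetyl again, but no measured compound shows what chloro at this place does on its own. The step of a number 26.4 percentage points higher from compound 2 to compound 3 (beyond the scatter) is therefore expected to run upward, back toward the number of compound 1, and beyond the scatter. Compound 3 is estimated at 35%. Its expected range runs from 10% to 60%.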

Compound 3, a percentage reported as inhibition, at one concentration (the size of the read-out at that concentration, not a potency): 4.11%
For compound 3 the middle estimate is 30.9 percentage points above the measured one, outside the stated range (below it).
By their numbers in this assay, from the lowest: compounds 3 and 2 (each within the scatter of the next); then compound 1.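

Read in this assay, chloro in place of hydrogen on this aromatic carbon gives a number 41.2 percentage points lower from compound 1 to compound 3 (beyond the scatter) and thereby matches the large loss seen with acetyl, so that loss is not confined to acetyl. Chloro in place of acetyl gives a number 4.5 percentage points lower from compound 2 to compound 3 (within the scatter) and so separates the two groups by no more than the scatter, even though acetyl brings a carbonyl and a hydrogen-bond acceptor and chloro brings neither. Among these three compounds, the place para to a large group therefore gives a clearly higher number only with hydrogen, while both groups placed there sit low together.

As far as these compounds go, whether the same loss follows with an amine, a hydroxyl or a carboxylic acid on this carbon remains open, and so does the outcome with a group as small as fluoro. From the compounds shown here alone, it is also open whether any group here can match or pass compound 1 at 45.3% in this assay, or whether the low numbers hold for every group at this place. Nothing at hand explains why the two groups give such similar numbers.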